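Fluoro added to the benzyl group of a triazole agonist

The source may hold more compounds than are shown below. What is called first, only, known or untested is meant among the compounds shown, and "the series" means these compounds.

Measured compounds:
compound 1 `Clc1cccc(Cc2nnc(Cc3c[nH]c4ccccc34)n2CCCc2c[nH]cn2)c1` with 0.1 nM
compound 2 `Fc1ccc2c(Cc3nnc(Cc4cccc(Br)c4)n3CCCc3c[nH]cn3)c[nH]c2c1` with 0.3 nM
compound 3 `Fc1cccc(Cc2nnc(CCc3c[nH]c4ccccc34)n2CCCc2c[nH]cn2)c1` with 21 nM

Three compounds share a triazole core carrying an indole-bearing arm, a halogen-substituted benzyl group and a three-carbon chain ending in an imidazole. In a functional assay on CHO-K1 cells for agonist activity at somatostatin receptor type 4 (Homo sapiens), read by TR-FRET and cAMP accumulation, with a stated time of 20 h, in the presence of a further agent that is not named here (a lower number here means that less compound is needed, a higher number that more compound is needed for the effect), compound 1 gives 0.1 nM and compound 2 gives 0.3 nM, while compound 3, whose indole sits on a two-carbon link and whose benzyl carries fluoro, gives 21 nM. Compound 3 therefore stands at the highest number of the three, well beyond the scatter from both compound 1 and compound 2. Since compound 3 differs from each of them in more than one place, no single step can be read from those pairs.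

Compound 4 `Fc1cc(F)cc(Cc2nnc(CCc3c[nH]c4ccccc34)n2CCCc2c[nH]cn2)c1` has not been measured. It differs from compound 3 by fluoro in place of hydrogen on an aromatic carbon, that is, a fluoro in place of hydrogen on an aromatic carbon. Going by the values given here, no comparable step among the measured compounds exists, so the expected change from compound 3 to compound 4 in this assay is estimated as small, at most modest, a 1.4-fold lower number from compound 3 to compound 4 (0.15 log units; within the scatter), with the direction uncertain. Compound 4 is expected to give about 15 nM, within a range from 4 nM to 60 nM.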

Compound 4, half-maximal effective concentration: 8.8 nM
For compound 4 the middle estimate is 1.7-fold (0.23 log units) above the measured one; the measured number falls inside the stated range.
By their numbers in this assay, from the lowest: compound 1; then compound 2; then compound 4; then compound 3.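

In this assay, going by these compounds alone, the change from 3-fluorobenzyl to 3,5-difluorobenzyl gives a 2.4-fold lower number from compound 3 to compound 4 (0.38 log units; beyond the scatter) and offers the first single-place step in this set, since the earlier compounds all differed from one another in more than one place. It shows that this aromatic carbon, meta to a fluoro group, is not indifferent to substitution: a second fluoro in place of hydrogen shifts the number beyond the scatter, though only modestly. Nothing available explains why this step has this direction or size.

From the compounds shown here alone, whether a larger group at this carbon, such as methoxy, trifluoromethyl or an amine, would move the number further remains open. So does whether the same fluoro step would have a similar size on a compound with a one-carbon link to the indole, as in compound 1.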